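Extending an ethylamino chain by one carbon on a triazine-free scaffold

The source may report more compounds than this note shows. Statements on the series, on what has been measured and on what is new or still open speak of the compounds shown alone.

Compound 1 `N#Cc1ccc(Nc2nc(N)nc(Oc3ccc(Cl)c4ccccc34)n2)cc1` and compound 2 `CCNc1nc(Nc2ccc(C#N)cc2)nc(Oc2ccc(Cl)c3ccccc23)n1` share the same core and are both measured in an ADME assay on MT4 cells (Homo sapiens) for cytotoxicity, read by MTT assay, with a stated time of 4 days; on this read-out lower numbers stand for higher toxicity in this test and higher numbers for lower toxicity in this test. In this assay compound 1 gives 237000 nM, while compound 2 gives 208000 nM. For the measured compounds named here, the only step measured so far, a 1.1-fold lower number from compound 1 to compound 2 (0.06 log units; within the scatter), comes from placing an ethyl in place of hydrogen on a nitrogen on an aromatic ring, and it stays within the scatter; so compound 2 sits alongside compound 1 with no real separation between the two numbers.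

Compound 3 `CCCNc1nc(Nc2ccc(C#N)cc2)nc(Oc2ccc(Cl)c3ccccc23)n1` extends that change by one carbon: methyl in place of hydrogen on a saturated chain carbon, two bonds along the chain from a nitrogen on an aromatic ring, which reads as ethylamino to propylamino. Going by the values given here, the single relevant precedent, the move from hydrogen to ethyl, produced no shift beyond the scatter, so a further small lengthening is expected to leave this assay essentially unchanged. Compound 3 is therefore estimated at 200000 nM, with a likely range from 100000 nM to 400000 nM, meaning an expected step of a 1.0-fold lower number from compound 2 to compound 3 (0.02 log units; within the scatter).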

Compound 3, half-maximal cytotoxic concentration: 182000 nM
Compound 3: the middle estimate sits 1.1-fold (0.04 log units) above what was measured, within the range that was stated.
By their numbers in this assay, from the lowest: compounds 3, 2 and 1 (each within the scatter of the next).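

In this assay, going from ethylamino to propylamino gives a 1.1-fold lower number from compound 2 to compound 3 (0.06 log units; within the scatter), so one more carbon on this saturated chain does not separate the two numbers. Reading the whole change at once, propyl in place of hydrogen on the nitrogen gives a 1.3-fold lower number from compound 1 to compound 3 (0.11 log units; within the scatter) and also stays within the scatter, so the three compounds, with hydrogen, ethyl and propyl at this nitrogen, cannot be told apart in this test. No outside data bear on this result.

From the compounds shown here alone, whether a longer chain such as butyl, a branched one such as isopropyl, or a chain ending in an amine or a carboxylic acid would also leave the number in place remains open. These compounds also leave open whether a ring, such as cyclopropyl, on this nitrogen would behave like the straight chains.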